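The source may report more compounds than this note shows. Statements on the series, on what has been measured and on what is new or still open speak of the compounds shown alone.

Measured so far in a physicochemical assay for lipophilicity, read by HPLC, with a stated time of 90 min, tested at 100 uM; on this read-out higher numbers stand for higher lipophilicity and lower numbers for lower lipophilicity:
compound 1 `O=C(Nc1ccc(OC(F)(F)F)c(F)c1)NC1CCN(C(=O)C2(C(F)(F)F)CC2)CC1`: 5.94
compound 2 `CCOC(=O)N1CCC(NC(=O)Nc2ccc(OC(F)(F)F)c(F)c2)CC1`: 5.94
compound 3 `CC(C)C(=O)N1CCC(NC(=O)Nc2ccc(OC(F)(F)F)c(F)c2)CC1`: 4.73

Compound 3 has the lowest number of the three, and the gap to each of the other two lies beyond the scatter. Compound 4 `O=C(Nc1ccc(OC(F)(F)F)c(F)c1)NC1CCN(C(=O)C2CCOCC2)CC1` has not been measured. It carries oxan-4-yl in place of isopropyl on a carbonyl carbon.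

Three measured steps involve a change on this same carbonyl carbon. Two are large: a number 1.21 log units lower from compound 1 to compound 3 (beyond the scatter) and a number 1.21 log units lower from compound 2 to compound 3 (beyond the scatter). The third, no change at the digits printed from compound 1 to compound 2 (within the scatter), shows that a swap there can also leave the number unchanged. None of them replaces isopropyl with oxan-4-yl, so they indicate how far the number can move here, but not which way it will move for this change. Among the measured compounds shown here, the data also contain no step that separates the effect of adding a ring from that of adding a hydrogen-bond acceptor.

No step beyond the scatter is expected, with a slight lean towards a lower number: the expected step is a number 0.23 log units lower from compound 3 to compound 4 (within the scatter). The range stays wide given the size of a number 1.21 log units lower from compound 2 to compound 3 (beyond the scatter). For compound 4 the estimated value is 4.5, with an expected range of 3.9 to 5.2.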

Compound 4, partition coefficient: 3.73
Estimate against measurement, compound 4: 0.77 log units above, and the stated range ends above it.
By their numbers in this assay, from the lowest: compound 4; then compound 3; then compounds 1 and 2 (each within the scatter of the next).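

In this assay, the carbonyl carbon whose other neighbour is the amide-type nitrogen in a ring allows a further drop below compound 3, with a number 1.00 log units lower from compound 3 to compound 4 (beyond the scatter). Measured against the other two groups at this place, oxan-4-yl gives a number 2.21 log units lower from compound 2 to compound 4 (beyond the scatter) and a number 2.21 log units lower from compound 1 to compound 4 (beyond the scatter), so the span at this single position is wider than the first three compounds showed, and compound 4 now marks its low end. More heavy atoms here do not bring a higher number in this pair: oxan-4-yl, with 6 heavy atoms, a six-membered ring and a hydrogen-bond acceptor, stands below isopropyl, with 3 heavy atoms, no ring and no acceptor.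

The compounds shown do not separate the contributions of the ring and its oxygen, and cyclohexyl on this carbonyl carbon would be the direct comparison with oxan-4-yl. No measurement available here gives a reason for the size of the drop.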